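The source may report more compounds than this note shows. Statements on the series, on what has been measured and on what is new or still open speak of the compounds shown alone.

Compound 1 `COc1ccc(-n2c(SC)nnc2-c2cc(OC)c(OC)c(OC)c2)cc1`: > 60000 nM
Compound 2 `COc1ccc(-n2c(SCc3ccc(C)cc3)nnc2-c2cc(OC)c(OC)c(OC)c2)cc1`: > 60000 nM
Compound 3 `COc1ccc(-n2c(SCc3ccc(F)cc3)nnc2-c2cc(OC)c(OC)c(OC)c2)cc1`: 50700 nM

For the measured compounds named here, in a functional assay on HT-29 cells (Homo sapiens) for inhibition, read by MTT assay, with a stated time of 48 h (a higher number here means a weaker inhibitor, a lower number a stronger inhibitor), compound 3 gives 50700 nM, the only true number in this small set. Compound 1 reads > 60000 nM, which is a limit of the assay and not a number. Compound 2 reads > 60000 nM, which is likewise a limit.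

Compound 4 `COc1ccc(-n2c(SCC(=O)C3CC3)nnc2-c2cc(OC)c(OC)c(OC)c2)cc1` differs from compound 3 in one place: cyclopropylcarbonyl in place of 4-fluorophenyl on a saturated chain carbon bound to a sulfur. In words, cyclopropylcarbonyl stands in place of 4-fluorophenyl on a saturated chain carbon bound to a sulfur.

Going by the values given here, no measured step makes this exact change, but three touch the same part of the molecule. Adding the 4-fluorophenyl group gives an at least 1.1-fold lower number from compound 1 to compound 3 (0.07 log units; that floor lies within the scatter). Adding the 4-methylphenyl group gives a step that the two limits leave unreadable from compound 1 to compound 2. Exchanging methyl for fluoro gives an at least 1.1-fold lower number from compound 2 to compound 3 (0.07 log units; that floor lies within the scatter). None of these shows a change beyond the scatter, so they offer no firm ground for expecting a shift in either direction in this assay.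

The expected change is a 1.0-fold lower number from compound 3 to compound 4 (0.01 log units; within the scatter), which is estimated to stay within the scatter. Compound 4 may also be expected to return only a limit, as seen in the limit of > 60000 nM in this assay, at which 2 of the 3 values shown sit. For compound 4 the estimated value is 50000 nM, with an expected range from 20000 nM to 80000 nM.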

Compound 4, half-maximal inhibitory concentration: > 60000 nM
Compound 4: only a limit was reported (the forecaster's own chance of this, stated with the estimate: 50%); middle value at least 1.2-fold (0.07 log units) away from the limit.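

Placing cyclopropylcarbonyl, with its carbonyl and its three-membered ring, where the aromatic 4-fluorophenyl stood gives an at least 1.1-fold higher number from compound 3 to compound 4 (0.07 log units; that floor lies within the scatter) in this assay, so this position has now carried a group with no aromatic ring and the printed floor of the step still does not go beyond the scatter. The steps that join compound 4 to compound 1 and to compound 2 run between two limits and cannot be read. Compound 3, with its 4-fluorophenyl, remains the only one with a true number, yet none of its steps is shown beyond the scatter, so none of the groups tried on this saturated chain carbon bound to a sulfur has a demonstrated advantage, and the values gather at the top of the range that can be read: the limit of > 60000 nM in this assay, at which 3 of the 4 values shown sit.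

As far as these compounds go, the true distance between compound 3 and compound 4 stays unknown, since the value of compound 4 is a limit and only a floor can be stated. From the compounds shown here alone, whether an amine, a carboxylic acid or a longer chain at this position would bring the number clearly down from that limit also remains open.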